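The source may report more compounds than this note shows. Statements on the series, on what has been measured and on what is new or still open speak of the compounds shown alone.

Compound 1 `CNC(=O)c1cc(C(=O)N[C@H]2[C@@H]3COC[C@@H]32)cc2c1OC[C@H]2c1cccnc1`, compound 2 `CNC(=O)c1cc(C(=O)N[C@H]2[C@@H]3COC[C@@H]32)cc2c1OC[C@H]2c1ccccc1` and compound 3 `CNC(=O)c1cc(C(=O)N[C@H]2[C@@H]3COC[C@@H]32)cc2c1OC[C@H]2c1ccncc1` differ only in the group on a saturated ring carbon. In a physicochemical assay for solubility (a lower number here means a less soluble compound, a higher number a more soluble compound), compound 1 gives >= 104 ug/mL, which is a limit and not a number. Compound 2 gives >= 165 ug/mL, also a limit. Compound 3 gives >= 184 ug/mL, again a limit. Compound 2 therefore has no exact place among the three, and no order can be read from them.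

Compound 4 `CNC(=O)c1cc(C(N)=O)cc2c1OC[C@H]2c1ccccc1` keeps the phenyl of compound 2 and differs elsewhere: a hydrogen atom in place of a group of 6 heavy atoms (5 carbon, 1 oxygen; one three-membered non-aromatic ring of carbon only, one five-membered non-aromatic ring with 1 hetero atom), on an amide-type nitrogen.

The measured steps are a step that the two limits leave unreadable from compound 1 to compound 2, a step that the two limits leave unreadable from compound 1 to compound 3 and a step that the two limits leave unreadable from compound 2 to compound 3. All three concern the group on the saturated ring carbon, not the amide-type nitrogen, and none has a readable size. They offer no guide to the size or direction of this change, so no shift beyond the usual scatter is expected in this assay. The expectation stays close to compound 2, whose >= 165 ug/mL is a limit. The expected change is an at least 1.1-fold lower number from compound 2 to compound 4 (0.04 log units; that floor lies within the scatter). The estimated value for compound 4 is 150 ug/mL. The expected range for compound 4 runs from 70 ug/mL to 320 ug/mL.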

Compound 4, solubility: >= 144 ug/mL
Compound 4 gave a limit, no number (the forecaster's own chance of this, stated with the estimate: 55%); the middle value does not contradict the limit.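

In this assay, compound 2 and compound 4 each give a limit and not a number, and the step between them cannot be read. The compounds shown leave open where the exact value of any of them lies, and whether the group on the saturated ring carbon or the group on the amide-type nitrogen changes it at all.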